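From a Heptyl Ester to a Free Hydroxy Group

A few compounds are considered here, and "the series" means these few. Any claim that something is new, unique, unknown or untested is made for them only; others in the source may bear on it.

Measured in a functional assay on A549 cells (Homo sapiens) for antiproliferative activity, read by MTT assay, with a stated time of 72 h; on this read-out lower numbers stand for stronger inhibition and higher numbers for weaker inhibition:
- compound 1 `CCCCCCCC(=O)Oc1cc(C(=O)C2=C3OC(C)(C)[C@@H](CC=C(C)C)C[C@@]34C[C@@H](CC=C(C)C)C(C)(C)[C@H]3CCC(C)(C)O[C@]34OC2=O)ccc1O`: > 20000 nM
- compound 2 `CC(C)=CC[C@H]1C[C@]23C[C@@H](CC=C(C)C)C(C)(C)[C@H]4CCC(C)(C)O[C@]42OC(=O)C(C(=O)c2ccc(OC(=O)c4ccc(F)cc4)c(OC(=O)c4ccc(F)cc4)c2)=C3OC1(C)C`: 11700 nM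
- compound 3 `CC(C)=CC[C@H]1C[C@]23C[C@@H](CC=C(C)C)C(C)(C)[C@H]4CCC(C)(C)O[C@]42OC(=O)C(C(=O)c2ccc(OC(=O)c4ccccc4)c(OC(=O)c4ccccc4)c2)=C3OC1(C)C`: > 20000 nM

The value for compound 1 is a limit of the assay and not a number. The value for compound 3 is also only a limit. Compound 1 therefore stands at the limit of > 20000 nM in this assay, at which 2 of the 3 values shown sit. Only compound 2 gives an actual number.

The next compound to be tested is compound 4 `CC(C)=CC[C@H]1C[C@]23C[C@@H](CC=C(C)C)C(C)(C)[C@H]4CCC(C)(C)O[C@]42OC(=O)C(C(=O)c2ccc(O)c(O)c2)=C3OC1(C)C`. It has hydrogen in place of heptylcarbonyl on an oxygen on an aromatic ring, so (heptylcarbonyl)oxy becomes hydroxy: hydrogen in place of heptylcarbonyl on an oxygen on an aromatic ring.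

For the measured compounds named here, no measured pair of compounds shows this change, so its size in this assay cannot be read from the data. A modest move toward lower numbers is expected, and this rests only on compound 2, whose 11700 nM shows that a compound with this shared core can give a number here. The estimated change is an at least 2.2-fold lower number from compound 1 to compound 4 (0.34 log units; beyond the scatter). The estimate for compound 4 is 9000 nM, with an expected range of 3000 nM to 20000 nM.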

Compound 4, half-maximal inhibitory concentration: > 20000 nM
Compound 4 was reported as a limit; the forecaster's own chance of this, stated with the estimate: 20%; middle value at least 2.2-fold (0.34 log units) from the limit.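

For the compounds shown here, compound 1 and compound 4 both give only a limit in this assay and not a number, and no step between them can be read. The compounds shown leave open how much, if at all, hydroxy in place of (heptylcarbonyl)oxy changes antiproliferative activity.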